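The source may report more compounds than this note shows. Statements on the series, on what has been measured and on what is new or still open speak of the compounds shown alone.

In an assay on isolated protein for inhibition of sphingomyelin phosphodiesterase (Homo sapiens), read by fluorescence, with a stated time of 30 min (a lower number here means a stronger inhibitor, a higher number a weaker inhibitor), compound 1 `CCc1nc(-c2ccc(COc3cccc(C(=O)NO)c3)cc2)no1` gives 34700 nM. Compound 2 `O=C(NO)c1cccc(OCc2ccc(-c3noc(-c4ccc(Br)cc4)n3)cc2)c1` reaches only the limit of this assay, > 100000 nM. Compound 3 `O=C(NO)c1cccc(OCc2ccc(-c3noc(-c4cccc(F)c4)n3)cc2)c1` likewise sits at the limit, > 100000 nM. The step of an at least 2.8-fold higher number from compound 1 to compound 2 (0.45 log units; beyond the scatter) and the step of an at least 2.8-fold higher number from compound 1 to compound 3 (0.45 log units; beyond the scatter) both show a weakening when an aryl group replaces ethyl, while the step that the two limits leave unreadable from compound 2 to compound 3 cannot be read because both of its values are limits (the limit of > 100000 nM in this assay, at which 2 of the 3 values shown sit). Compound 3 thus stands at the weak end of what has been measured, with no number of its own.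

Compound 4 `O=C(NO)c1cccc(OCc2ccc(-c3noc(Cc4ccccc4)n3)cc2)c1` differs from compound 3 by benzyl in place of 3-fluorophenyl on an aromatic carbon. Within the data shown here, the steps that bear on this change are the two from compound 1 to the aryl compounds, each at least modest and both toward a higher number. The benzyl of compound 4, unlike the 3-fluorophenyl of compound 3 and the 4-bromophenyl of compound 2, is not itself an aryl group on the core, and a partial return toward the value of compound 1, 34700 nM, is therefore plausible. That compound 4 too sits at the limit of this assay cannot be excluded. Compound 4 is expected to give about 60000 nM in this assay, within 20000 nM to 200000 nM. This expectation corresponds to the step of an at least 1.6-fold lower number from compound 3 to compound 4 (0.22 log units; that floor lies within the scatter).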

Compound 4, half-maximal inhibitory concentration: 7830 nM
Estimate against measurement, compound 4: 7.7-fold (0.88 log units) above; the measured number lies below the stated range.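

In this assay, among these compounds, the earlier compounds showed only a loss when an aryl group replaced ethyl at this position, whereas benzyl gives a stronger result than ethyl itself (a 4.4-fold lower number from compound 1 to compound 4 (0.65 log units; beyond the scatter)), as phenyl takes the place of methyl on the chain carbon. The 3-fluorophenyl and 4-bromophenyl groups, like benzyl, each carry one six-membered aromatic ring, yet the changes to benzyl are large (an at least 12-fold lower number from compound 3 to compound 4 (1.10 log units; beyond the scatter) and an at least 12-fold lower number from compound 2 to compound 4 (1.10 log units; beyond the scatter)), so the presence of that ring alone does not decide the result here. Those two steps are floors and not full sizes: the limit of > 100000 nM in this assay, at which 2 of the 4 values shown sit.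

The compounds shown leave open whether a longer chain such as phenethyl would extend this gain. They also leave open how a methoxy group or a fluorine on the benzyl group, or an amine in its place, would change the value.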